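Swapping the Aryl Group on a Shared Core

The source may report more compounds than this note shows. Statements on the series, on what has been measured and on what is new or still open speak of the compounds shown alone.

Compound 1 `CCOc1nc(-c2cc3ccccc3o2)cc(-c2ccc(Cl)cc2Cl)c1C#N` gives 442000 nM in a functional assay on aorta (strain Wistar) for inhibition, with Thoracic aorta (Rattus norvegicus) as the target; on this read-out higher numbers stand for weaker inhibition and lower numbers for stronger inhibition.
Compound 2 `CCOc1nc(-c2cc3ccccc3o2)cc(-c2ccc(OC)cc2OC)c1C#N` gives 488000 nM in this assay.
Compound 3 `CCOc1nc(-c2cc3ccccc3o2)cc(-c2ccc(N(C)C)cc2)c1C#N` gives 338000 nM in this assay.

Compound 3 holds the lowest of the three numbers, yet a 1.3-fold lower number from compound 1 to compound 3 (0.12 log units; within the scatter) and a 1.4-fold lower number from compound 2 to compound 3 (0.16 log units; within the scatter) both fall within the scatter, as does a 1.1-fold higher number from compound 1 to compound 2 (0.04 log units; within the scatter). On this read-out the three aryl groups cannot be told apart. Compound 4 `CCOc1nc(-c2cc3ccccc3o2)cc(-c2cn(C)c3ccccc23)c1C#N` carries 1-methyl-1H-indol-3-yl in place of 4-(dimethylamino)phenyl on an aromatic carbon, the new group sitting ortho to a cyano group and opposite the ring nitrogen. Going by the values given here, no measured step involves an indolyl group, so only the three aryl exchanges bear on this change, and all of them stayed within the scatter. Compound 4 is therefore expected to show a 1.1-fold higher number from compound 3 to compound 4 (0.05 log units; within the scatter), a step not beyond the scatter. Compound 4 is estimated at 380000 nM in this assay, within a range of 150000 nM to 950000 nM.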

Compound 4, half-maximal inhibitory concentration: 327000 nM
Beside the measured number, compound 4's estimate is 1.2-fold (0.07 log units) above it; the measured number falls inside the stated range.
By their numbers in this assay, from the lowest: compounds 4, 3, 1 and 2 (each within the scatter of the next).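

In this assay the position opposite the ring nitrogen now also takes 1-methyl-1H-indol-3-yl, with its five-membered aromatic ring, and the read-out stays flat: a 1.0-fold lower number from compound 3 to compound 4 (0.01 log units; within the scatter) and a 1.5-fold lower number from compound 2 to compound 4 (0.17 log units; within the scatter) and a 1.4-fold lower number from compound 1 to compound 4 (0.13 log units; within the scatter) all lie within the scatter. The indifference seen among substituted phenyl groups therefore extends to this different ring type, and the four compounds cannot be told apart. Nothing at hand explains this flatness.

Still open, on these data alone, is whether a saturated amine such as piperidine, a carboxylic acid or a longer alkyl chain here would move the number beyond the scatter. Also open, as far as these compounds go, is whether replacing the ethoxy or 1-benzofuran-2-yl group would do so.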